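Dihydropyridine series: propyl replaced by 2-cyanoethenyl

The source may report more compounds than this note shows. Statements on the series, on what has been measured and on what is new or still open speak of the compounds shown alone.

Measured so far:
compound 1 `CCCC1=C(C(=O)OCC)C(c2cccc([N+](=O)[O-])c2)C(C(=O)OCC)=C(C)N1` — 105 nM
compound 2 `CCOC(=O)C1=C(C)NC(CO)=C(C(=O)OCC)C1c1cccc([N+](=O)[O-])c1` — 45 nM

In a functional assay on HEK293 cells for antagonist activity at Voltage-dependent L-type calcium channel subunit alpha-1D (Rattus norvegicus), read by FLIPR (a higher number here means a weaker inhibitor, a lower number a stronger inhibitor), compound 1 gives the highest of the two numbers; compound 2 sits at the lower one, the step being a 2.3-fold lower number from compound 1 to compound 2 (0.37 log units; beyond the scatter). Compound 3 `CCOC(=O)C1=C(C)NC(/C=C/C#N)=C(C(=O)OCC)C1c1cccc([N+](=O)[O-])c1` differs from compound 1 by 2-cyanoethenyl in place of propyl on a double-bonded ring carbon. Among the compounds with values here, the only step that bears on this position is that from compound 1 to compound 2, a modest one for a different replacement at the same carbon. For compound 3 a small step in this assay is therefore expected, if any, in either direction. Compound 3 is estimated at 75 nM, range 25 nM to 250 nM, which would mean an expected 1.4-fold lower number from compound 1 to compound 3 (0.15 log units; within the scatter).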

Compound 3, half-maximal inhibitory concentration: 45 nM
Compound 3: middle estimate off by 1.7-fold (0.22 log units), on the high side; measured number inside the range.
By their numbers in this assay, from the lowest: compounds 2 and 3 (each within the scatter of the next); then compound 1.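

In this assay the change gives a 2.3-fold lower number from compound 1 to compound 3 (0.37 log units; beyond the scatter) and so shows that a second, quite different replacement of propyl at this carbon, one carrying a nitrile, also lowers the number. There is no change at the digits printed from compound 2 to compound 3 (within the scatter) so hydroxymethyl and 2-cyanoethenyl cannot be told apart here. No supporting data bear on why these two replacements match.

Going by these compounds, whether the double bond or the nitrile matters remains open, and a saturated 2-cyanoethyl group would separate the two. Also open, on these data alone, is how an amine, a carboxylic acid or a longer chain would read at this carbon.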